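Aryl swap on the sulfonamide nitrogen of compound 3

The compounds below may be only part of what the source reports. "The series", "measured", "known", "first", "only" and "open" are said of these compounds alone.

In a functional assay on MCF7 cells (Homo sapiens) for inhibition, read by CCK-8 assay, with a stated time of 72 h (on this read-out lower numbers stand for stronger inhibition and higher numbers for weaker inhibition), compound 1 `O=C(/C=C/c1cccnc1)NCCCCCc1ccc(S(=O)(=O)Nc2ccccc2)cc1` gives 95.7 nM, compound 2 `O=C(/C=C/c1cccnc1)NCCCCCCc1ccc(S(=O)(=O)Nc2ccccc2)cc1` gives 36 nM and compound 3 `Cc1ccccc1NS(=O)(=O)c1cccc(CCCCCCNC(=O)/C=C/c2cccnc2)c1` gives 0.226 nM. Compound 3 has the lowest number of the three, beyond the scatter from both others, with compound 2 the nearest.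

Next is compound 4 `CC(C)(C)c1ccc(NS(=O)(=O)c2cccc(CCCCCCNC(=O)/C=C/c3cccnc3)c2)cc1`, which carries 4-(tert-butyl)phenyl in place of 2-methylphenyl on a sulfonamide nitrogen. Among the measured compounds shown here, no measured pair isolates a change at this place, so the expectation is loose. A rise beyond the scatter is expected in this assay, resting on the very low value of compound 3 at 0.226 nM. The estimated step is an 18-fold higher number from compound 3 to compound 4 (1.25 log units; beyond the scatter). For compound 4 the expected value is 4 nM, within an estimated range of 0.4 nM to 40 nM.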

Compound 4, half-maximal inhibitory concentration: 26.3 nM
Estimate against measurement, compound 4: 6.6-fold (0.82 log units) below, and the stated range covers the measured number.
By their numbers in this assay, from the lowest: compound 3; then compounds 4 and 2 (each within the scatter of the next); then compound 1.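

Among the compounds shown here, this is the first step read at this place: with the rest of the molecule unchanged, 4-(tert-butyl)phenyl in place of 2-methylphenyl on the sulfonamide nitrogen gives a 120-fold higher number from compound 3 to compound 4 (2.07 log units; beyond the scatter) in this assay. The read-out is therefore highly sensitive to the aryl group here, and 2-methylphenyl is the better of the two groups compared. Open, on these data alone, is whether the step follows the loss of 2-methylphenyl or the entry of 4-(tert-butyl)phenyl, which a plain phenyl, a 4-methylphenyl or a 2-(tert-butyl)phenyl on this same core could separate. No measurement at hand bears on what lies behind a step of this size.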